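This account rests on a few compounds, and the source may have more. Where it says the series, first, only, none or still open, it means among the compounds named here.

Measured compounds:

compound 1, `COc1cc2c(/C=C3/C(=O)Nc4ccc(Cl)cc43)c(Cl)n(Cc3cc(OC)c(OC)c(OC)c3)c2cc1C` — 6030 nM
compound 2, `COc1ccc2c(c1)/C(=C\c1c(Cl)n(Cc3cc(OC)c(OC)c(OC)c3)c3cc(C)c(OC)cc13)C(=O)N2` — 75900 nM
compound 3, `COc1c(/C=C2/C(=O)Nc3ccc(Cl)cc32)c2ccccc2n1-c1ccccc1` — 19100 nM

All three were run in a functional assay on cells (Cancer cell lines, Homo sapiens) for cytotoxicity, with a stated time of 48 h; on this read-out lower numbers stand for stronger inhibition of growth and higher numbers for weaker inhibition of growth. Compound 1 gives 6030 nM and compound 3 gives 19100 nM; compound 2 gives 75900 nM. For the measured compounds named here, the single counted change within the measured set, (methoxy in place of chloro on an aromatic carbon), produced a 13-fold higher number from compound 1 to compound 2 (1.10 log units; beyond the scatter).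

Compound 4, `COc1ccc2c(c1)/C(=C\c1c(OC)n(-c3ccccc3)c3ccccc13)C(=O)N2`, has not yet been run in this assay. It is made from compound 3 by methoxy in place of chloro on an aromatic carbon. The place of this change is described in the same words as for the step from compound 1 to compound 2, so it is the same change on a different core. How the core of compound 3 differs from that of compound 1 is not broken down here.

Going by the values given here, only one prior instance of this change exists, and it was made on another core, so the expectation rests on a single step. Compound 4 is expected to weaken, with an estimated 7.9-fold higher number from compound 3 to compound 4 (0.90 log units; beyond the scatter), beside the earlier step of a 13-fold higher number from compound 1 to compound 2 (1.10 log units; beyond the scatter). For compound 4 the estimate is 150000 nM, with a range of 40000 nM to 500000 nM.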

Compound 4, concentration for total growth inhibition: 9550 nM
The estimate for compound 4 lay 16-fold (1.20 log units) above the measured number; the measured number lies below the stated range.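

In this assay, methoxy in place of chloro on an aromatic carbon does not behave as a fixed shift that can be carried from one core to another: the same change on two cores in this assay, a 13-fold higher number (1.10 log units; beyond the scatter) from compound 1 to compound 2 and a 2.0-fold lower number (0.30 log units; within the scatter) from compound 3 to compound 4, 25-fold (1.40 log units) apart, beyond the scatter of two such steps On the core of compound 3 the step is a 2.0-fold lower number from compound 3 to compound 4 (0.30 log units; within the scatter), so the swap gives no readable change there, while on the core of compound 1 it gives a 13-fold higher number from compound 1 to compound 2 (1.10 log units; beyond the scatter). This shows that the outcome of the swap depends on the core in these two pairs, but the cores differ in more than one place, and the pairs do not show which difference goes with the gap or how a third core would respond.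

Open, as far as these compounds go, is how an amine or a carboxylic acid on this aromatic carbon would compare with chloro and methoxy on either core. Also open, from the compounds shown here alone, is how the swap behaves on a core that carries only one of the differences between compound 1 and compound 3.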